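The source may hold more compounds than are shown below. What is called first, only, known or untested is meant among the compounds shown, and "the series" means these compounds.

Measured so far in an ADME assay (liver) for pharmacokinetics, with Liver microsome (Homo sapiens) as the target, using microsomes; a higher number here means that the compound lasts longer, a lower number that the compound disappears faster:
- compound 1 `CCOc1cc(NC(=O)C2(NC(=O)c3ccc4c(C5CCCC5)c(-c5ncc(Cl)cn5)n(C)c4c3)CCC2)ccc1/C=C/C(=O)OC(=O)C[C@H](O)C(=O)O`: 5.57 h
- compound 2 `CCOc1cc(NC(=O)C2(NC(=O)c3ccc4c(C5CCCC5)c(-c5ncc(Cl)cn5)n(C)c4c3)CCC2)ccc1/C=C/C(=O)OCC(C)C`: > 5 h, a limit of the assay and not a number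
- compound 3 `CCOc1cc(NC(=O)C2(NC(=O)c3ccc4c(C5CCCC5)c(-c5ncc(Cl)cn5)n(C)c4c3)CCC2)ccc1/C=C/C(=O)OCC(=O)OC`: 2.1 h

Among the two numbers in this assay, compound 1 stands highest; its nearest neighbour is compound 3, reached by a 2.7-fold lower number from compound 1 to compound 3 (0.42 log units; beyond the scatter). The step that the limit leaves unreadable from compound 1 to compound 2 cannot be sized because of the limit of > 5 h in this assay, at which 1 of the 3 values shown sits. The step of an at least 2.3-fold lower number from compound 2 to compound 3 (0.37 log units; beyond the scatter) does read as a lowering.

Compound 4 `CCCN(C)C(=O)COC(=O)/C=C/c1ccc(NC(=O)C2(NC(=O)c3ccc4c(C5CCCC5)c(-c5ncc(Cl)cn5)n(C)c4c3)CCC2)cc1OCC` differs from compound 1 in one place: (methyl(propyl)carbamoyl)methyl in place of (2-carboxy-2-hydroxyethyl)carbonyl on an oxygen next to a carbonyl group. For the measured compounds named here, the one readable step on the same oxygen, a 2.7-fold lower number from compound 1 to compound 3 (0.42 log units; beyond the scatter), also puts a carbonyl-bearing two-carbon group in place of the (2-carboxy-2-hydroxyethyl)carbonyl, and it lowered the half-life modestly; the (methyl(propyl)carbamoyl)methyl entering in compound 4 is of the same pattern. A modest lowering in this assay is therefore expected, with a 1.9-fold lower number from compound 1 to compound 4 (0.27 log units; within the scatter) as the estimated step. For compound 4 the expected half-life in this assay is 3 h, estimated to fall between 1.5 h and 6 h.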

Compound 4, half-life: 0.317 h
Estimate against measurement, compound 4: 9.5-fold (0.98 log units) above, outside the stated range (below it).
By their numbers in this assay, from the lowest: compound 4; then compound 3; then compound 1.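

On an oxygen next to a carbonyl group, this position proves far more sensitive in this assay than compounds 1 to 3 suggested, with an 18-fold lower number from compound 1 to compound 4 (1.24 log units; beyond the scatter), a large step. Compounds 3 and 4 both carry a carbonyl-bearing group on that oxygen, yet methyl(propyl)amino in place of methoxy on a carbonyl carbon gives a 6.6-fold lower number from compound 3 to compound 4 (0.82 log units; beyond the scatter), so what sits on that carbonyl carbon matters as well as the carbonyl itself. Methyl(propyl)carbamoyl in place of isopropyl gives an at least 15-fold lower number from compound 2 to compound 4 (1.19 log units; beyond the scatter), and the value of compound 2 is a limit and not a number: the limit of > 5 h in this assay, at which 1 of the 4 values shown sits.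

Going by these compounds, it remains open whether the lowering belongs to the amide as such or to its propyl chain; a dimethylamino or a morpholine on the same carbonyl carbon would separate the two. The compounds shown also do not tell which bond is lost in the microsomes.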